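The compounds below may be only part of what the source reports. "The series", "measured", "known", "first", "only" and "open" are said of these compounds alone.

Working notes on the series. The shared core is carried by compound 1 `CCc1ccc(Nc2ncnc3cc(OC)c(OCCCCC(=O)Nc4ccc(S(N)(=O)=O)cc4)cc23)cc1` and compound 2 `NS(=O)(=O)c1ccc(NC(=S)Nc2ccc3ncnc(Nc4ccc(F)c(Br)c4)c3c2)cc1`. In a functional assay on A-431 cells (Homo sapiens) for antiproliferative activity, read by MTT assay, with a stated time of 72 h (a higher number here means a weaker inhibitor, a lower number a stronger inhibitor), compound 1 gives 7220 nM. In this assay, going by the values given here, compound 2 gives 18200 nM, the highest of the two numbers recorded so far; the gap to compound 1 lies beyond the scatter, and no single-point step connects the two.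

Compound 3 `Cc1ccc(Nc2ncnc3ccc(NC(=S)Nc4ccc(S(N)(=O)=O)cc4)cc23)cc1` is not yet measured in this assay. Relative to compound 2 it differs in one place: 4-methylphenyl in place of 3-bromo-4-fluorophenyl on a nitrogen on an aromatic ring. Among the compounds with values here, no measured pair shows this change, so its size in this assay rests on nothing firmer than the two numbers above; a modest step in either direction, or none beyond the scatter, would be unsurprising.

Compound 3 is therefore estimated near 20000 nM in this assay, within 5000 nM to 80000 nM, which means an expected step of a 1.1-fold higher number from compound 2 to compound 3 (0.04 log units; within the scatter).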

Compound 3, half-maximal inhibitory concentration: 40000 nM
Compound 3: the middle estimate sits 2.0-fold (0.30 log units) below what was measured; the measured number falls inside the stated range.
By their numbers in this assay, from the lowest: compound 1; then compound 2; then compound 3.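

In this assay, going by these compounds alone, (4-methylphenyl)amino in place of (3-bromo-4-fluorophenyl)amino gives a 2.2-fold higher number from compound 2 to compound 3 (0.34 log units; beyond the scatter), the first single-point step. The group on this nitrogen is therefore not silent: with the rest of compound 2 held constant, changing it alone moves the number beyond the scatter, towards weaker inhibition. Nothing available bears on why the step runs in this direction.

Bromine and fluorine leave together as the methyl enters, so this one step cannot assign the shift to any of the three. As far as these compounds go, whether 3-bromophenyl, 4-fluorophenyl or unsubstituted phenyl on this nitrogen would fall nearer compound 2 or compound 3 remains open, as does whether the step would keep its size and direction with another group in place of the thiourea-linked benzenesulfonamide.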